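A few compounds are considered here, and "the series" means these few. Any claim that something is new, unique, unknown or untested is made for them only; others in the source may bear on it.

In a functional assay on HOS cells (Homo sapiens) for antiproliferative activity, with a stated time of 72 h (a higher number here means a weaker inhibitor, a lower number a stronger inhibitor), compound 1 `OC[C@H]1O[C@@H](n2cnc3c(NCc4cccc(Br)c4)ncnc32)[C@H](O)[C@@H]1O` gives > 166000 nM, which is a limit of the assay and not a number. Compound 2 `OC[C@H]1O[C@@H](n2cnc3c(NCc4ccc(F)cc4Cl)ncnc32)[C@H](O)[C@@H]1O` gives > 166000 nM, which is also a limit. The record therefore stands at the limit of > 166000 nM in this assay, at which 2 of the 2 values shown sit. For the measured compounds named here, the one measured step, a step that the two limits leave unreadable from compound 1 to compound 2, bears on the question only weakly, as it has no readable size and shows no direction. Compound 3 `OC[C@H]1O[C@@H](n2cnc3c(NCc4cc(O)cc(O)c4)ncnc32)[C@H](O)[C@@H]1O` keeps the shared core, and the change sits on a saturated chain carbon bound to a nitrogen on an aromatic ring: 3,5-dihydroxyphenyl in place of 2-chloro-4-fluorophenyl on a saturated chain carbon bound to a nitrogen on an aromatic ring. Unlike the group it replaces, 3,5-dihydroxyphenyl brings hydrogen-bond donors and acceptors, a kind of change that neither measured compound tests. A second limit is the likeliest outcome, with a modest shift towards a stronger inhibitor as the only readable alternative. The expected change is an at least 1.3-fold lower number from compound 2 to compound 3 (0.14 log units; that floor lies within the scatter). For compound 3, the estimated value is 120000 nM, with an expected range from 20000 nM to 250000 nM.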

Compound 3, half-maximal inhibitory concentration: > 166000 nM
Compound 3 gave a limit, no number; the forecaster's own chance of this, stated with the estimate: 65%; middle value at least 1.3-fold (0.14 log units) from the limit.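

Compound 3 ends at a limit of the assay, not a number, just as compound 1 and compound 2 do, so no step among these three compounds can be read: the limit of > 166000 nM in this assay, at which 3 of the 3 values shown sit. The compounds shown leave open how strongly any of the three acts and whether any group at this place would give a readable number.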